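Swapping Trifluoromethyl for Methylsulfanyl: What Exposure to Expect

The source may hold more compounds than are shown below. What is called first, only, known or untested is meant among the compounds shown, and "the series" means these compounds.

Compound 1 `COc1ccc(C2=C(c3ccc(SC)cc3)CC3CCCN3C2=O)cc1OC`: 40500 ng.h/mL
Compound 2 `CSc1ccc(C2=C(c3ccc(C(F)(F)F)cc3)C(=O)N3CCCC3C2)cc1`: 4330 ng.h/mL

The two compounds were measured in an ADME assay on the whole organism with Mus musculus as the target, at a dose of 200 mg/kg by the intraperitoneal route (on this read-out higher numbers stand for higher exposure at the dose given and lower numbers for lower exposure), and differ by more than the usual scatter of repeated measurements. Compound 2 stands lowest of the two at 4330 ng.h/mL while compound 1 reaches 40500 ng.h/mL on the same scale.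

The step of interest leads from compound 2 to compound 3 `CSc1ccc(C2=C(c3ccc(SC)cc3)C(=O)N3CCCC3C2)cc1` which has not yet been measured. In this step, methylsulfanyl takes the place of trifluoromethyl on an aromatic carbon, para to a large group methylsulfanyl in place of trifluoromethyl on an aromatic carbon and the rest of the structure stays the same.

Among the measured compounds shown here, no measured pair differs in one place only, so the data give no direct guide to the size of this change. Compound 3 lacks trifluoromethyl, as does compound 1 at 40500 ng.h/mL and this is slim support for expecting a rise in this assay somewhat beyond the scatter. The expected change is a 3.2-fold higher number from compound 2 to compound 3 (0.51 log units; beyond the scatter) as an estimate with wide uncertainty. For compound 3 the estimated value is 14000 ng.h/mL with an expected range from 4500 ng.h/mL to 45000 ng.h/mL in this measurement.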

Compound 3, area under the concentration-time curve: 954 ng.h/mL
Estimate against measurement, compound 3: 15-fold (1.17 log units) above; measured number outside the range, below it.
By their numbers in this assay, from the lowest: compound 3; then compound 2; then compound 1.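

In this assay, the exchange on this aromatic carbon now has a direct reading: the step gives a 4.5-fold lower number from compound 2 to compound 3 (0.66 log units; beyond the scatter) with the rest of the structure unchanged. Trifluoromethyl and methylsulfanyl are therefore not interchangeable at this place, even though neither group carries a ring or a net charge; compound 1 also lacks trifluoromethyl, but it differs from compound 3 in more than one place, so its high number cannot be set against this step. Nothing measured here accounts for the fall in exposure at the dose given, so this single step records its direction and size but not its cause.

Going by these compounds, whether a chlorine atom, a nitrile or a longer chain such as ethylsulfanyl at this same place would give a number nearer to that of compound 2 or to that of compound 3 remains open. Also open, on these data alone, is whether the same exchange would lower exposure on the core of compound 1, or at another dose or by another route of dosing, since one step on one core cannot establish a general trend.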